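The source may report more compounds than this note shows. Statements on the series, on what has been measured and on what is new or still open speak of the compounds shown alone.

Compound 1 `Cc1noc(C)c1-c1cc(NC(=O)CCCCCC(=O)NO)cc(C(=O)c2ccccc2)c1`: 0.92 degrees C. Compound 2 `Cc1noc(C)c1-c1cc(NC(=O)CCCCCCC(=O)NO)cc(C(=O)c2ccccc2)c1`: 1.35 degrees C.

Going by the values given here, in an assay for binding affinity to histone acetyltransferase KAT2B (Homo sapiens), tested at 25 uM (on this read-out lower numbers stand for weaker stabilisation of the target and higher numbers for stronger stabilisation of the target against heat), compound 1 stands lowest of the two numbers, and compound 2 lies nearest to it. a number 0.43 degrees C higher from compound 1 to compound 2 (within the scatter) is the only measured step; it concerns the chain, not the ring, so it does not bear directly on the change to compound 3 `Cc1noc(C)c1-c1cccc(NC(=O)CCCCCC(=O)NO)c1`, which is hydrogen in place of benzoyl on an aromatic carbon. Among the compounds with values here, with no step touching this position, the expected change is a number 0.52 degrees C lower from compound 1 to compound 3 (within the scatter), leaning lower but not beyond the scatter. For compound 3 the estimate is 0.4 degrees C, between -0.7 degrees C and 1.5 degrees C.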

Compound 3, shift of the target's melting temperature: 0.05 degrees C
Compound 3: the middle estimate sits 0.35 degrees C above what was measured; low and high end bracket the measured number.
By their numbers in this assay, from the lowest: compounds 3, 1 and 2 (each within the scatter of the next, the first and the last beyond it).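

In this assay, going by these compounds alone, compound 3 gives 0.05 degrees C, the first reading at this aromatic carbon, since the earlier step concerned only the chain. Hydrogen in place of benzoyl gives a number 0.87 degrees C lower from compound 1 to compound 3 (within the scatter), so losing all eight heavy atoms of the benzoyl group, including its aromatic ring and carbonyl, produces no step beyond the scatter.

On these data alone, whether an amine or a carboxylic acid on this aromatic carbon would give a step beyond the scatter stays open. Nothing available explains the step at this position.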